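Methyl on the phenyl arm: expectation before measurement

The source may hold more compounds than are shown below. What is called first, only, known or untested is meant among the compounds shown, and "the series" means these compounds.

Measured so far:
compound 1 `Cc1[nH]c2ccccc2c1C1=C(Br)C(=O)C(c2c(C)[nH]c3ccccc23)=C(Br)C1=O`: 5.55 ug/mL
compound 2 `Cc1[nH]c2ccccc2c1C1=C(Cl)C(=O)C(c2c(-c3ccccc3)[nH]c3ccccc23)=C(Cl)C1=O`: 4.46 ug/mL

In a functional assay on MDA-MB-231 cells (Homo sapiens) for antiproliferative activity, read by CCK-8 assay, with a stated time of 48 h (on this read-out higher numbers stand for weaker inhibition and lower numbers for stronger inhibition), compound 1 gives 5.55 ug/mL and compound 2 gives 4.46 ug/mL. Compound 2 has the lower of the two numbers, but the gap to compound 1 lies within the usual scatter, so the two are not separated on this read-out. For the measured compounds named here, no pair of measured compounds differs in a single place, so no step size has yet been observed.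

Compound 3 `Cc1ccc(-c2[nH]c3ccccc3c2C2=C(Cl)C(=O)C(c3c(C)[nH]c4ccccc34)=C(Cl)C2=O)cc1` differs from compound 2 by methyl in place of hydrogen on an aromatic carbon. Without any measured single-point step to lean on, the expected step of a 1.0-fold higher number from compound 2 to compound 3 (0.00 log units; within the scatter) is none beyond the scatter, in either direction. Compound 3 is therefore estimated at 4.5 ug/mL, with a range from 2.2 ug/mL to 9 ug/mL.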

Compound 3, half-maximal inhibitory concentration: 4.21 ug/mL
Estimate against measurement, compound 3: 1.1-fold (0.03 log units) above; the measured number falls inside the stated range.
By their numbers in this assay, from the lowest: compounds 3, 2 and 1 (each within the scatter of the next).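

For the compounds shown here, this is the first single-place step: in this assay, the change from phenyl to 4-methylphenyl gives a 1.1-fold lower number from compound 2 to compound 3 (0.03 log units; within the scatter). Methyl in place of hydrogen at this aromatic carbon, para to a large group, therefore leaves the two compounds unseparated on this read-out, so the position accepts this one added carbon without a resolved shift in either direction. No measured data on the series offer an explanation for this result.

On these data alone, whether a different group here, such as an amine, a carboxylic acid or a longer chain, would move the number beyond the scatter remains open. Also open, as far as these compounds go, is whether methyl elsewhere on the phenyl arm, or the same change with other atoms on the shared core, would give an equally small step.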